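Working notes: aryl in place of benzyl on the ring nitrogen

The source may hold more compounds than are shown below. What is called first, only, known or untested is meant among the compounds shown, and "the series" means these compounds.

Compound 1 `CCCn1c(=O)[nH]c2nc(-c3ccc(S(=O)(=O)N4CCN(Cc5cccc(Br)c5)CC4)cc3)[nH]c2c1=O` gives 23% in an assay on CHO cells for displacement of a labelled ligand from adenosine receptor A3 (Homo sapiens), read by scintillation counting, with a stated time of 45 min, tested at 1 uM, in the presence of a further agent that is not named here; on this read-out higher numbers stand for more inhibition at the one concentration tested (going by the name of the read-out) and lower numbers for less inhibition.
Compound 2 `CCCn1c(=O)[nH]c2nc(-c3ccc(S(=O)(=O)N4CCN(Cc5ccc(Br)c(F)c5)CC4)cc3)[nH]c2c1=O` gives 27% in this assay.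

Compound 2 and compound 1 sit within the scatter of each other: the step of a number 4 percentage points higher from compound 1 to compound 2 (within the scatter) does not separate them, so no order between the two is claimed. Compound 3 `CCCn1c(=O)[nH]c2nc(-c3ccc(S(=O)(=O)N4CCN(c5ccc(C)cc5)CC4)cc3)[nH]c2c1=O` differs from compound 2 thus: 4-methylphenyl in place of 4-bromo-3-fluorobenzyl on an amine nitrogen in a ring. Going by the values given here, the only measured step, a number 4 percentage points higher from compound 1 to compound 2 (within the scatter), alters substituents on the benzyl ring and keeps the benzyl link, so it does not bear on this change. No basis for a direction exists; compound 3 is expected near 24%, within 5% to 48%, a step of a number 3 percentage points lower from compound 2 to compound 3 (within the scatter) with wide uncertainty.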

Compound 3, a percentage reported as inhibition, at one concentration (the size of the read-out at that concentration, not a potency): 25%
For compound 3 the middle estimate is 1 percentage points below the measured one; measured number inside the range.
By their numbers in this assay, from the lowest: compounds 1, 3 and 2 (each within the scatter of the next).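

In this assay, 4-methylphenyl in place of 4-bromo-3-fluorobenzyl on the amine nitrogen in a ring gives a number 2 percentage points lower from compound 2 to compound 3 (within the scatter), and in place of 3-bromobenzyl it gives a number 2 percentage points higher from compound 1 to compound 3 (within the scatter). The earlier step kept the benzyl link; this change removes it, and neither step separates the aryl compound from the benzyl compounds. No supporting data bear on this result. Open, as far as these compounds go, is whether a different group on this nitrogen, such as a chain carrying a carboxylic acid or an amine, would give a number beyond the scatter of these three compounds.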